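A Dichlorophenyl Sulfonyl Variant of a Weak Growth Inhibitor

A few compounds are considered here, and "the series" means these few. Any claim that something is new, unique, unknown or untested is made for them only; others in the source may bear on it.

Compound 1 `CC(=O)Nc1ccc(S(=O)(=O)NNC(=O)c2cccnc2Nc2ccc(Cl)cc2)cc1` and compound 2 `O=C(NNS(=O)(=O)c1ccc(F)cc1)c1cccnc1Nc1ccc(Cl)cc1Cl` share a core and have both been tested in a functional assay on HT-29 cells (Homo sapiens) for antiproliferative activity; a lower number here means a stronger inhibitor of growth, a higher number a weaker inhibitor of growth. For compound 1 the result is a limit of the assay, > 100000 nM, and no number is given. In this assay compound 2 gives 57500 nM. The two differ in more than one place, so their values show only that each is a weak growth inhibitor. Compound 1 stands at the limit of > 100000 nM in this assay, at which 1 of the 2 values shown sits.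

Compound 3 `O=C(NNS(=O)(=O)c1ccc(Cl)cc1Cl)c1cccnc1Nc1ccc(Cl)cc1` has not yet been measured. It differs from compound 1 in one place: 2,4-dichlorophenyl in place of 4-acetamidophenyl on a sulfonyl sulfur. No measured step of this kind exists among these compounds, so the expectation rests on compound 1 alone. Compound 3 is expected to come off the limit by a step of an at least 1.6-fold lower number from compound 1 to compound 3 (0.22 log units; that floor lies within the scatter), toward stronger growth inhibition. In this assay compound 3 is therefore estimated at 60000 nM, with a likely range from 20000 nM to 200000 nM, and a fair chance that the assay again reports only a limit.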

Compound 3, concentration for total growth inhibition: 53700 nM
Compound 3: middle estimate off by 1.1-fold (0.05 log units), on the high side; the measured number falls inside the stated range.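

For the compounds shown here, at this place, on a sulfonyl sulfur whose other neighbour is the sulfonamide nitrogen, putting 2,4-dichlorophenyl in place of 4-acetamidophenyl gives a first reading of this change in this assay: an at least 1.8-fold lower number from compound 1 to compound 3 (0.27 log units; that floor lies within the scatter). The entering group has no hydrogen-bond donor or acceptor, and compound 3, at 53700 nM, remains a weak growth inhibitor. The true size of the step stays unknown because compound 1 gives a limit and not a number: the limit of > 100000 nM in this assay, at which 1 of the 3 values shown sits.

The compounds shown leave open whether a phenyl ring with only one chlorine would read the same as the 2,4-dichlorophenyl group. They also leave open how an amine or a carboxylic acid on the ring at this sulfonyl sulfur would read in this assay.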